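Chloro for fluoro on the saturated ring carbon

The source may hold more compounds than are shown below. What is called first, only, known or untested is meant among the compounds shown, and "the series" means these compounds.

In a functional assay (Platelet, plasma) for inhibition, with Homo sapiens as the target (on this read-out higher numbers stand for weaker inhibition and lower numbers for stronger inhibition), compound 3 (`N#Cc1cc2c(nc1N1CCC(C(=O)NS(=O)(=O)Cc3ccccc3)CC1)CCC(F)C2=O`) gives 255000 nM, the highest number of the three. Compound 2 (`N#Cc1cc2c(nc1N1CCC(C(=O)NS(=O)(=O)Cc3ccccc3)CC1)CCCC2=O`) gives 117000 nM and compound 1 (`N#Cc1cc2c(nc1N1CCC(F)(C(=O)NS(=O)(=O)Cc3ccc(Cl)cc3)CC1)COC2=O`) gives 37200 nM. Compound 4 (`N#Cc1cc2c(nc1N1CCC(C(=O)NS(=O)(=O)Cc3ccccc3)CC1)CCC(Cl)C2=O`) has chloro in place of fluoro on a saturated ring carbon. Within the data shown here, the one measured step that bears on this change is a 2.2-fold higher number from compound 2 to compound 3 (0.34 log units; beyond the scatter), modest in size, with fluoro in place of hydrogen on a saturated ring carbon. Among the measured compounds shown here, no measured compound carries chloro there, so the direction remains open, and no step beyond the scatter is expected in this assay. The estimated step is a 1.1-fold lower number from compound 3 to compound 4 (0.04 log units; within the scatter). For compound 4 the expected value is 230000 nM, with an estimated range of 110000 nM to 480000 nM.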

Compound 4, half-maximal inhibitory concentration: > 300000 nM
Compound 4 ended at the assay's limit; the forecaster's own chance of this, stated with the estimate: 15%; middle value at least 1.3-fold (0.11 log units) from the limit.
By their numbers in this assay, from the lowest: compound 1; then compound 2; then compound 3. At a limit, above all of these: compound 4.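

In this assay compound 4 gives > 300000 nM, which is a limit of the assay and not a number: the limit of > 300000 nM in this assay, at which 1 of the 4 values shown sits.

Chloro in place of hydrogen on the saturated ring carbon gives an at least 2.5-fold higher number from compound 2 to compound 4 (0.40 log units; beyond the scatter), so a second halogen at this position now moves the number the same way as fluoro, which gave a 2.2-fold higher number from compound 2 to compound 3 (0.34 log units; beyond the scatter). Chloro in place of fluoro gives an at least 1.1-fold higher number from compound 3 to compound 4 (0.07 log units; that floor lies within the scatter), and with that floor inside the scatter the two halogens cannot be ordered.

Still open, from the compounds shown here alone, is whether a hydroxyl or an amine on this ring carbon would bring the number down rather than up. Going by these compounds, how far chloro truly lies from fluoro also stays open.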